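A Methyl Where a Methoxy Once Stood

A few compounds are considered here, and "the series" means these few. Any claim that something is new, unique, unknown or untested is made for them only; others in the source may bear on it.

Going by the values given here, compound 2 `O=c1[nH]c2ccccc2cc1-c1nc2cc(F)ccc2[nH]1` is the one member of this set that returns a number in a functional assay on NCI-H460 cells (Homo sapiens) for cytotoxicity, read by MTT assay, with a stated time of 48 h (on this read-out higher numbers stand for weaker inhibition and lower numbers for stronger inhibition), where compound 2 gives 24200 nM. Compound 1 `COc1ccc2[nH]c(=O)c(-c3nc4cc(F)ccc4[nH]3)cc2c1` reaches only the limit of the assay in this assay, giving > 100000 nM. Compound 3 `O=c1[nH]c2ccccc2cc1-c1nc2cc([N+](=O)[O-])ccc2[nH]1` likewise reaches only the limit in this assay, giving > 100000 nM. Compound 2 therefore stands alone on the numbers, the two remaining values sitting at the limit (the limit of > 100000 nM in this assay, at which 2 of the 3 values shown sit).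

Compound 4 `Cc1ccc2[nH]c(=O)c(-c3nc4cc(F)ccc4[nH]3)cc2c1` differs from compound 2 by methyl in place of hydrogen on an aromatic carbon. The step that bears on it most closely is an at least 4.1-fold lower number from compound 1 to compound 2 (0.61 log units; beyond the scatter), in which a methoxy on that aromatic carbon was replaced by hydrogen; the step of an at least 4.1-fold higher number from compound 2 to compound 3 (0.61 log units; beyond the scatter) concerns a different substituent exchange and speaks only indirectly. Since a substituent at this carbon went with a higher number in compound 1 > 100000 nM, one expects a modest rise for compound 4, a 2.1-fold higher number from compound 2 to compound 4 (0.32 log units; beyond the scatter). Compound 4 is thus estimated at 50000 nM in this assay, within a range from 15000 nM to 150000 nM.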

Compound 4, half-maximal inhibitory concentration: > 100000 nM
Compound 4: a limit, no number (the forecaster's own chance of this, stated with the estimate: 35%); middle value at least 2.0-fold (0.30 log units) away from the limit.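

In this assay, methyl in place of hydrogen on this aromatic carbon gives an at least 4.1-fold higher number from compound 2 to compound 4 (0.61 log units; beyond the scatter). The loss seen with methoxy is therefore not confined to that group: a single carbon at this position is enough, and among the compounds carrying the fluoro group, only compound 2, with hydrogen here, returns a number, while compound 3 goes against any simple rule by keeping hydrogen here and still giving no number. The step between compound 1 and compound 4 cannot be read, so methyl and methoxy cannot be ranked against each other, since both sit at the same limit: the limit of > 100000 nM in this assay, at which 3 of the 4 values shown sit.

On these data alone, it remains open how far past the limit compound 1 and compound 4 lie. As far as these compounds go, it is also open whether an amine or a carboxylic acid on this carbon would return a number at all.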